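Swapping methoxy for fluoro on the anilino ring

A few compounds are considered here, and "the series" means these few. Any claim that something is new, unique, unknown or untested is made for them only; others in the source may bear on it.

Measured compounds:
compound 1 `COc1ccc(C(=O)c2sc(Nc3ccccc3)c(C(=O)O)c2C)cc1` — 24.7%
compound 2 `COc1ccc(Nc2sc(C(=O)c3ccc(OC)cc3)c(C)c2C(=O)O)cc1` — 23.5%

Of the compounds shown here, two sharing one core have been tested in a functional assay, with a stated time of 150 min, tested at 10 ug/mL; a higher number here means a stronger effect of the compound at the concentration tested, a lower number a weaker effect. Compound 1 `COc1ccc(C(=O)c2sc(Nc3ccccc3)c(C(=O)O)c2C)cc1` gives 24.7%, and compound 2 `COc1ccc(Nc2sc(C(=O)c3ccc(OC)cc3)c(C)c2C(=O)O)cc1` gives 23.5%. Compound 2 holds the lower of the two numbers, but the step of a number 1.2 percentage points lower from compound 1 to compound 2 (within the scatter) lies within the scatter, so the two compounds cannot be told apart on this reading.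

Compound 3 `COc1ccc(C(=O)c2sc(Nc3ccc(F)cc3)c(C(=O)O)c2C)cc1` has not been measured. It differs from compound 2 by fluoro in place of methoxy on an aromatic carbon, taking (4-methoxyphenyl)amino to (4-fluorophenyl)amino. Among the measured compounds shown here, the only measured step that touches this position is a number 1.2 percentage points lower from compound 1 to compound 2 (within the scatter), where adding the methoxy group changed nothing beyond the scatter. For the measured compounds named here, with that step as the sole guide, a flat outcome is expected: the estimated step of a number 0.5 percentage points higher from compound 2 to compound 3 (within the scatter) is no larger than the scatter. Compound 3 is therefore estimated at 24%, within a range from 14% to 34%.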

Compound 3, a percentage reported as activity, at one concentration (the size of the read-out at that concentration, not a potency): 0.98%
Beside the measured number, compound 3's estimate is 23 percentage points above it, outside the stated range (below it).
By their numbers in this assay, from the lowest: compound 3; then compounds 2 and 1 (each within the scatter of the next).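

In this assay the step of a number 22.5 percentage points lower from compound 2 to compound 3 (beyond the scatter) puts fluoro in place of methoxy, and the step of a number 23.7 percentage points lower from compound 1 to compound 3 (beyond the scatter) puts fluoro in place of hydrogen on the same aromatic carbon. The position is therefore not indifferent to what it carries, as the methoxy step alone had left it looking: hydrogen and methoxy cannot be told apart here, while fluoro stands clearly apart from both. Nothing available explains why fluoro differs from the other two on this ring.

On these data alone, it remains open whether this loss belongs to fluoro alone or would also follow from chloro, a nitrile or an amine on this carbon. The compounds shown also do not say whether the same separation would hold at other concentrations in this assay or with fluoro elsewhere on the ring.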